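Methyl for Chloro on the Aniline Ring: Cytotoxicity Outlook

The source may report more compounds than this note shows. Statements on the series, on what has been measured and on what is new or still open speak of the compounds shown alone.

Compound 1 `Cc1ccc(NCc2cn(-c3ccccc3)nc2-c2ccc(Cl)cc2)cc1`: > 100000 nM
Compound 2 `Cc1ccc(NCc2cn(-c3ccccc3)nc2-c2ccc(Br)cc2)cc1`: > 100000 nM
Compound 3 `Clc1ccc(NCc2cn(-c3ccccc3)nc2-c2ccccc2)cc1`: 65000 nM

Of the compounds shown here, three sharing one core have been tested in an ADME assay on Vero 76 cells (Chlorocebus sabaeus) for cytotoxicity, read by MTT assay, with a stated time of 96 h; a lower number here means that less compound is tolerated, a higher number that more compound is tolerated. Compound 1 reaches only a limit of this assay, > 100000 nM, and no number. Compound 2 likewise sits at a limit, > 100000 nM. Among the measured compounds shown here, compound 3 is the one compound with a number in this assay, 65000 nM. For the measured compounds named here, the one step between measured neighbours, a step that the two limits leave unreadable from compound 1 to compound 2, is bromo in place of chloro on an aromatic carbon, and the two limits make its size unreadable, so it gives no guidance on size.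

Compound 4 `Cc1ccc(NCc2cn(-c3ccccc3)nc2-c2ccccc2)cc1` arises from compound 3 by methyl in place of chloro on an aromatic carbon. Going by the values given here, no measured step bears directly on this change. What the data offer is the limit of > 100000 nM in this assay, at which 2 of the 3 values shown sit, which suggests that this class of compounds tends not to show toxicity within the tested window. A step from compound 3 to compound 4 of about a 1.4-fold higher number from compound 3 to compound 4 (0.14 log units; within the scatter) is therefore expected, within the scatter or modestly upward. Compound 4 is estimated to give 90000 nM in this assay, between 45000 nM and 200000 nM, with a fair chance that only a limit is reported.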

Compound 4, half-maximal cytotoxic concentration: > 100000 nM
Compound 4: no number, only a limit; the forecaster's own chance of this, stated with the estimate: 50%; middle value at least 1.1-fold (0.04 log units) from the limit.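

Among the compounds shown here, replacing chloro with methyl on the aromatic carbon para to a large group gives the only readable step at this position in this assay: an at least 1.5-fold higher number from compound 3 to compound 4 (0.18 log units; that floor lies within the scatter). Only a floor is known for this step, and that floor lies within the scatter, so the result shows that the change from 4-chlorophenyl to 4-methylphenyl leaves the compound at the limit of the assay, but it does not fix the size of the step. Compound 3 is now the one compound shown with a number rather than a limit, and it stands against an otherwise uniform picture in which the other compounds share the same limit: the limit of > 100000 nM in this assay, at which 3 of the 4 values shown sit.

The steps from compound 1 and from compound 2 to compound 4 run between two limits and cannot be read, so the effect of the chloro and bromo groups on the other phenyl ring remains unresolved. The compounds shown also leave open how far compound 4 lies beyond its limit, and whether a methoxy group, an amine or a carboxylic acid at the place of the methyl would give a number or a limit.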